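The source may report more compounds than this note shows. Statements on the series, on what has been measured and on what is new or still open speak of the compounds shown alone.

Compound 1 `Oc1ccccc1-c1cc(-c2cccs2)cc(-c2ccccc2O)n1` gives in a functional assay on HeLa cells (Homo sapiens) for cytotoxicity, read by CCK-8 assay (on this read-out lower numbers stand for stronger inhibition and higher numbers for weaker inhibition), a limit, > 50000 nM. Compound 2 `Oc1ccc(-c2cc(-c3cccs3)cc(-c3cccc(O)c3)n2)cc1` gives in this assay a number, 4140 nM. Compound 3 `Oc1ccccc1-c1cc(-c2ccsc2)cc(-c2ccccc2O)n1` gives in this assay only a limit, > 50000 nM.

Compound 3 therefore stands at the limit of > 50000 nM in this assay, at which 2 of the 3 values shown sit, so its place among the measured compounds cannot be fixed. Among the compounds with values here, the one measured step that leads to it, a step that the two limits leave unreadable from compound 1 to compound 3, is unreadable for the same reason. Compound 4 `Oc1ccc(-c2cc(-c3ccsc3)cc(-c3ccccc3O)n2)cc1` arises from compound 3 by 4-hydroxyphenyl in place of 2-hydroxyphenyl on an aromatic carbon. Within the data shown here, no measured step shows this change alone. Compound 2 carries a 4-hydroxyphenyl group and a 3-hydroxyphenyl group on the shared core and gives a number where compound 1, with two 2-hydroxyphenyl groups, gives a limit; this pair differs in more than one place, so only the two values can be compared, and they hint that a hydroxyl moved away from the 2-position of the phenyl ring is compatible with a readable number. In this assay compound 4 is therefore expected to give 20000 nM, between 5000 nM and 60000 nM, an expected step of an at least 2.5-fold lower number from compound 3 to compound 4 (0.39 log units; beyond the scatter), with a fair chance that only a limit is reported again.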

Compound 4, half-maximal inhibitory concentration: > 50000 nM
Compound 4: only a limit was reported; the forecaster's own chance of this, stated with the estimate: 40%; middle value at least 2.5-fold (0.39 log units) from the limit.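

In this assay compound 4 gives only a limit, > 50000 nM. No step can be read between compound 3 and compound 4 because both sit at that limit: the limit of > 50000 nM in this assay, at which 3 of the 4 values shown sit.

The compounds shown leave open whether 4-hydroxyphenyl in place of 2-hydroxyphenyl changes the read-out at all on its own.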